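The compounds below may be only part of what the source reports. "The series", "measured", "known", "first", "only" and "open" are said of these compounds alone.

Three compounds in this set share a sulfonyl-linked vinyl bridge between a methoxyphenyl ring and a pyridine ring, and all three have been tested in an ADME assay on BV-2 cells (Mus musculus) for cytotoxicity, with a stated time of 24 h, tested at 50 uM; on this read-out lower numbers stand for a stronger effect and higher numbers for a weaker effect at the one concentration tested. Compound 1 `COc1ccccc1S(=O)(=O)/C=C/c1ccccn1` gives 100% in this assay. Compound 2 `COc1ccccc1S(=O)(=O)/C=C/c1ncccc1Cl` carries one extra group, and in this assay compound 2 gives 100%. The change between them is chloro in place of hydrogen on an aromatic carbon, and its size is no change at the digits printed from compound 1 to compound 2 (within the scatter).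

Compound 3 `COc1cccc(S(=O)(=O)/C=C/c2cccnc2)c1` is built from the same atoms as compound 1, joined differently; how the two cores differ is not broken down here. In this assay compound 3 gives 90.8%, which lies within the scatter of the other two values, so no order among the three can be read from these numbers.

Compound 4 `COc1cccc(S(=O)(=O)/C=C/c2cccnc2Cl)c1` has not yet been measured. It arises from compound 3 by chloro in place of hydrogen on an aromatic carbon. Among the measured compounds shown here, this is the same kind of change as the one from compound 1 to compound 2, though the surroundings differ: in compound 4 the chloro sits next to the ring nitrogen, whereas in compound 2 it sits two atoms from the ring nitrogen. For the measured compounds named here, the step from compound 3 to compound 4 is expected to be a number 1.2 percentage points higher from compound 3 to compound 4 (within the scatter), a judgment resting on compounds 1 and 2, because no change at the digits printed from compound 1 to compound 2 (within the scatter) is the only precedent for this change. Compound 4 is therefore estimated to give 92% in this assay, somewhere between 78% and 100%.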

Compound 4, a percentage reported as activity, at one concentration (the size of the read-out at that concentration, not a potency): 78.8%
Compound 4: middle estimate off by 13.2 percentage points, on the high side; the range from low to high includes it.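

In this assay, chloro in place of hydrogen on an aromatic carbon gives a number 12 percentage points lower from compound 3 to compound 4 (beyond the scatter), and on the other core the same change gives no change at the digits printed from compound 1 to compound 2 (within the scatter). Only the first of these steps stands clear of the scatter by itself, yet set side by side the two steps cannot be told apart: the same change on two cores in this assay, no change at the digits printed (within the scatter) from compound 1 to compound 2 and a number 12 percentage points lower (beyond the scatter) from compound 3 to compound 4, 12 percentage points apart, within the scatter of two such steps

This does not show that the core decides what the chloro does, and it does not show that the step carries over unchanged from one core to the other; with a single pair on each core, the size of this step on a further core cannot be foretold.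

From the compounds shown here alone, it remains open whether a fluoro, a bromo or an amine in place of the chloro of compound 4 would give a number close to that of compound 4 or close to that of compound 3. Also open, going by these compounds, is how far the step from hydrogen to chloro would hold at other concentrations, as this assay reports the size of the effect at a single concentration and gives no potency.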